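A fluoro-to-chloro swap at the limit of the assay

A few compounds are considered here, and "the series" means these few. Any claim that something is new, unique, unknown or untested is made for them only; others in the source may bear on it.

Compound 1 `O=C(CSC(=S)N[C@H]1CCOC1=O)Nc1ccccc1F` gives > 128000 nM (a limit)
Compound 2 `O=C(CSC(=S)N[C@H]1CCOC1=O)Nc1ccc(Cl)cc1` gives > 128000 nM (a limit)
Compound 3 `Cc1cccc(NC(=O)CSC(=S)N[C@H]2CCOC2=O)c1` gives > 128000 nM (a limit)

In a functional assay on EC9706 cells (Homo sapiens) for cytotoxicity, read by MTT assay, with a stated time of 72 h (on this read-out lower numbers stand for stronger inhibition and higher numbers for weaker inhibition), compound 1 gives > 128000 nM as a limit and not as a number. The three measured compounds share one reading (the limit of > 128000 nM in this assay, at which 3 of the 3 values shown sit) so compound 1 offers no number to start from.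

The step to compound 4 `O=C(CSC(=S)N[C@H]1CCOC1=O)Nc1ccccc1Cl` puts chloro in place of fluoro on an aromatic carbon and turns 2-fluorophenyl into 2-chlorophenyl. Among the measured compounds shown here, three measured steps bear on it, all changes to the same phenyl group: (a step that the two limits leave unreadable from compound 1 to compound 2) and (a step that the two limits leave unreadable from compound 1 to compound 3) and (a step that the two limits leave unreadable from compound 2 to compound 3). None of them has a readable size.

On the strength of the limit of > 128000 nM in this assay, at which 3 of the 3 values shown sit, in this assay no step beyond the scatter is expected, and no direction can be given. The expected change is a number no higher from compound 1 to compound 4 (the limit leaves the size open) on this estimate. Compound 4 is expected to stay at or near the limit, with an estimated value of 128000 nM and an estimated range (50000 nM to 256000 nM).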

Compound 4, half-maximal inhibitory concentration: > 128000 nM
Compound 4 ended at the assay's limit (the forecaster's own chance of this, stated with the estimate: 85%); the middle value lies on the limit itself.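

Compound 4 gives > 128000 nM, again a limit and not a number, so none of its steps from compound 1, compound 2 or compound 3 can be read. The compounds shown leave open whether any change to this phenyl group would give a measurable value in this assay.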